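Carbonyl substituent series on the shared core

A few compounds are considered here, and "the series" means these few. Any claim that something is new, unique, unknown or untested is made for them only; others in the source may bear on it.

Going by the values given here, compound 2 `Cc1nc(S(C)(=O)=O)ccc1Oc1ncnc(OC2CCN(C(=O)SC3CCC3)CC2)c1F` gives 8.51 nM in a functional assay on isolated protein for inhibition of Glucose-dependent insulinotropic receptor (Homo sapiens), read by HTRF and cAMP accumulation (on this read-out higher numbers stand for an effect only at larger amounts of compound and lower numbers for an effect already at smaller amounts), the lowest of the two numbers measured; the only neighbour is compound 1 `Cc1nc(S(C)(=O)=O)ccc1Oc1ncnc(OC2CCN(C(=O)OC3COC3)CC2)c1F`, which gives 326 nM. Among the compounds with values here, the one step measured so far, a 38-fold lower number from compound 1 to compound 2 (1.58 log units; beyond the scatter), shows that exchanging the group on the carbonyl carbon can move the number a long way. Compound 3 `Cc1nc(S(C)(=O)=O)ccc1Oc1ncnc(OC2CCN(C(=O)C3(C)CC3)CC2)c1F` is not yet measured and differs from compound 2 at the same place: 1-methylcyclopropyl in place of cyclobutylsulfanyl on a carbonyl carbon. Within the data shown here, no measured step covers a 1-methylcyclopropyl group, so the direction rests on the size alone of the change from compound 1 to compound 2. Because that step was a 38-fold lower number from compound 1 to compound 2 (1.58 log units; beyond the scatter), some loss from the group that leaves is expected, though a smaller one than in that step. Compound 3 is estimated at 25 nM, with a range from 6 nM to 100 nM. The expected step is a 2.9-fold higher number from compound 2 to compound 3 (0.47 log units; beyond the scatter).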

Compound 3, half-maximal effective concentration: 761 nM
Beside the measured number, compound 3's estimate is 30-fold (1.48 log units) below it; the whole stated range lies below it.
By their numbers in this assay, from the lowest: compound 2; then compound 1; then compound 3.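

In this assay the low number at this carbonyl carbon now belongs to cyclobutylsulfanyl alone, as 1-methylcyclopropyl in its place gives a large rise (an 89-fold higher number from compound 2 to compound 3 (1.95 log units; beyond the scatter)) and so shows that a small carbon ring here does not by itself keep compound 2's level. Against (oxetan-3-yl)oxy the same group gives a modest rise (a 2.3-fold higher number from compound 1 to compound 3 (0.37 log units; beyond the scatter)) and leaves compound 3 with the highest number of the three. Nothing at hand explains these steps, and the ring and the sulfur change together in the step from compound 2, so their separate shares cannot be told.

From the compounds shown here alone, what cyclobutyloxy or cyclobutylamino would give on the same carbonyl carbon stays open, and with it whether the sulfur or the four-membered ring goes with the low number of compound 2. All three compounds carry the shared core, so whether these steps hold on any other core is also unknown.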